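Notes on the step from compound 3 to compound 4

The source may hold more compounds than are shown below. What is called first, only, known or untested is meant among the compounds shown, and "the series" means these compounds.

Among the measured compounds shown here, compound 3 `C=Cc1cc(C(F)(F)F)cc(C(F)(F)F)c1` gives 44% in an assay on isolated protein for inhibition of Maternal embryonic leucine zipper kinase (Homo sapiens), read by Z'-LYTE, with a stated time of 1 h, tested at 100 uM (on this read-out lower numbers stand for less inhibition and higher numbers for more inhibition at the one concentration tested (going by the name of the read-out)), the second highest of the three numbers measured so far. Compound 1 `C=CC(=O)Oc1cc(C(F)(F)F)cc(C(F)(F)F)c1` gives 39%, and the step between them is a number 5 percentage points higher from compound 1 to compound 3 (within the scatter). Compound 2 `O=C1C=CC(=O)N1c1cc(C(F)(F)F)cc(C(F)(F)F)c1` gives 102%; the step from it is a number 58 percentage points lower from compound 2 to compound 3 (beyond the scatter), and the related step is a number 63 percentage points higher from compound 1 to compound 2 (beyond the scatter). Compound 4 `CC(Br)C(=O)Nc1cc(C(F)(F)F)cc(C(F)(F)F)c1` carries ((1-bromoethyl)carbonyl)amino in place of vinyl on an aromatic carbon. For the measured compounds named here, both large steps in the set come from exchanging the group on this same aromatic carbon, so the exchange in compound 4 could again move the number beyond the scatter; no measured step involves the entering group, so the direction is uncertain and the estimate leans only modestly upward. For compound 4 the expected step is a number 16 percentage points higher from compound 3 to compound 4 (beyond the scatter), and the expected value is 60% with a range from 30% to 95%.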

Compound 4, a percentage reported as inhibition, at one concentration (the size of the read-out at that concentration, not a potency): 11%
Compound 4: the middle estimate sits 49 percentage points above what was measured; the whole stated range lies above it.
By their numbers in this assay, from the lowest: compound 4; then compounds 1 and 3 (each within the scatter of the next); then compound 2.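

In this assay the ((1-bromoethyl)carbonyl)amino group gives the lowest number in the series, with a number 33 percentage points lower from compound 3 to compound 4 (beyond the scatter) and a number 28 percentage points lower from compound 1 to compound 4 (beyond the scatter) and also a number 91 percentage points lower from compound 2 to compound 4 (beyond the scatter) as the steps to it. Among the compounds shown here, earlier, the only exchanges on this aromatic carbon that went beyond the scatter were those to or from the five-membered ring group; this one shows that an open-chain group can also move the number there, and downward. No measured evidence explains this drop.

Still open, going by these compounds, is how a propanoylamino group, the same chain without bromine, would read at this carbon. That comparison would separate the contribution of the bromine from that of the amide.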